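Cytotoxicity notes on a triazole series: methoxy for methyl

The compounds below may be only part of what the source reports. "The series", "measured", "known", "first", "only" and "open" are said of these compounds alone.

Measured so far:
compound 1, `CC[C@H](CCn1cncn1)c1ccc(OC)cc1`: 118 ug/mL
compound 2, `CCC[C@H](CCn1cncn1)c1ccc(C)cc1`: 47.2 ug/mL

Both compounds were tested in an ADME assay on RD cells (Homo sapiens) for cytotoxicity, read by MTT assay, with a stated time of 3 days; on this read-out higher numbers stand for lower toxicity in this test and lower numbers for higher toxicity in this test. Compound 1 gives 118 ug/mL, and compound 2 gives 47.2 ug/mL. Within the data shown here, compound 2 stands at the lowest of the two numbers; the only other value, that of compound 1, is higher, and the gap between the two is beyond the usual scatter of repeated measurements.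

Next in line is compound 3, `CCC[C@H](CCn1cncn1)c1ccc(OC)cc1`, not yet measured in this assay. Relative to compound 2 the change is methoxy in place of methyl on an aromatic carbon; nothing else in the structure moves.

Among the measured compounds shown here, no measured pair in the set isolates this single change, so the size of the step is open. What is known is that the compound carrying the methoxy group, compound 1, gives the higher number, 118 ug/mL, while compound 2 with the methyl gives 47.2 ug/mL. On that basis the step is expected to run upward, probably of modest size and possibly within the scatter; the expected step is a 1.7-fold higher number from compound 2 to compound 3 (0.23 log units; within the scatter). Compound 3 is estimated at 80 ug/mL, with a range from 35 ug/mL to 180 ug/mL.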

Compound 3, half-maximal cytotoxic concentration: 59.3 ug/mL
Compound 3: the middle estimate sits 1.3-fold (0.13 log units) above what was measured, and the stated range covers the measured number.
By their numbers in this assay, from the lowest: compounds 2, 3 and 1 (each within the scatter of the next, the first and the last beyond it).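

In this assay, methoxy in place of methyl on an aromatic carbon, para to a large group, now has a pair that isolates it: a 1.3-fold higher number from compound 2 to compound 3 (0.10 log units; within the scatter) and thus no step beyond the scatter on this core, even with the hydrogen-bond acceptor that methoxy brings in. The second pair isolates methyl in place of hydrogen on a saturated chain carbon, three bonds along the chain from an aromatic carbon, and gives a 2.0-fold lower number from compound 1 to compound 3 (0.30 log units; within the scatter) so that this single change also stays within the scatter, as does the aromatic change. Nothing at hand bears on what lies behind either step.

Among these compounds, whether an amine or a carboxylic acid on the same aromatic carbon would give a step beyond the scatter remains open, as does the outcome for a longer chain than the one in compound 3. Among the compounds shown here, also open is whether the methoxy for methyl step keeps its size on the shorter chain of compound 1, since the set holds only one pair for that change.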